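Sulfonyl for carbonyl on the ring nitrogen of compound 1

This account rests on a few compounds, and the source may have more. Where it says the series, first, only, none or still open, it means among the compounds named here.

Three compounds of the shared core have numbers in a functional assay on A549 cells (Homo sapiens) for antiproliferative activity, read by MTT assay, with a stated time of 72 h; a lower number here means a stronger inhibitor, a higher number a weaker inhibitor. Compound 1 `CN(C(=O)c1ccc(Cl)cc1)c1ccc2[nH]c(-c3n[nH]c4ccccc34)cc2n1` gives 2220 nM, the lowest number of the three. Among the measured compounds shown here, compound 2 `CN(C(=O)c1ccccc1)c1ccc2[nH]c(-c3n[nH]c4cc(Cl)ccc34)cc2n1` gives 9590 nM in this assay, and compound 3 `CN(C(=O)c1ccccc1)c1ccc2[nH]c(-c3n[nH]c4cc(C#N)ccc34)cc2n1` gives 32800 nM; the single one-place step, a 3.4-fold higher number from compound 2 to compound 3 (0.53 log units; beyond the scatter), concerns the ring bearing the chloro or cyano group and not the nitrogen substituent.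

Compound 4 `Cc1ccc(S(=O)(=O)N(C)c2ccc3[nH]c(-c4n[nH]c5ccccc45)cc3n2)cc1` differs from compound 1 in one place: (4-methylphenyl)sulfonyl in place of (4-chlorophenyl)carbonyl on a nitrogen on an aromatic ring. For the measured compounds named here, no measured step touches this nitrogen substituent, so the measured step from compound 2 to compound 3 offers only a sense of the scale of effects seen, not a direction. The change is expected to move this assay by a modest amount, direction uncertain, with a somewhat higher number slightly favoured since compound 1 already holds the lowest value: the estimated step is a 1.8-fold higher number from compound 1 to compound 4 (0.26 log units; within the scatter). For compound 4 the expected value in this assay is 4000 nM, with a range from 1000 nM to 16000 nM.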

Compound 4, half-maximal inhibitory concentration: 27100 nM
Compound 4: the middle estimate sits 6.8-fold (0.83 log units) below what was measured; the measured number lies above the stated range.
By their numbers in this assay, from the lowest: compound 1; then compound 2; then compounds 4 and 3 (each within the scatter of the next).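

In this assay, among the compounds shown here, this is the first measured change at the nitrogen substituent, and the exchange gives a 12-fold higher number from compound 1 to compound 4 (1.09 log units; beyond the scatter) on the shared core, so (4-methylphenyl)sulfonyl cannot stand in for (4-chlorophenyl)carbonyl at this place without a large loss. The step changes the carbonyl to a sulfonyl and the chloro to a methyl together, so the two changes cannot be told apart from this pair. Nothing available explains the size of this step.

Still open, going by these compounds, is which of the two changes carries the loss, a question that (4-chlorophenyl)sulfonyl or (4-methylphenyl)carbonyl on this nitrogen would address. Also open, on these data alone, is how the series responds to an acetyl group at this place, or to an ethyl chain in place of the saturated chain carbon on the same nitrogen.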